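This account rests on a few compounds, and the source may have more. Where it says the series, first, only, none or still open, it means among the compounds named here.

Two measured compounds share one core, carrying a chloromethyl-substituted benzyl group on a fused two-ring system. Compound 1 `ClCc1cccc(Cn2cnc3ncnc(Cl)c32)c1` and compound 2 `ClCc1cccc(Cn2cnc3c(Cl)ncnc32)c1` differ only in where the chloro group sits on that fused system. In a functional assay on RPMI-8226 cells (Homo sapiens) for cytotoxicity, read by sulforhodamine B assay, with a stated time of 48 h (a lower number here means a stronger inhibitor of growth, a higher number a weaker inhibitor of growth), compound 2 gives 16200 nM, the lowest of the two numbers recorded. In this assay compound 1 gives 34700 nM, a higher number, and the gap between the two lies beyond the usual scatter of repeated measurements.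

Compound 3 `ClCc1cccc(Cn2cnc3c(Cl)nc(Cl)nc32)c1` is the next compound and has not yet been measured. Compared with compound 2, the change is chloro in place of hydrogen on an aromatic carbon. Going by the values given here, no pair among the measured compounds shows what adding a second chloro group does here, so the expectation rests on compound 2 alone. The expected step is a 1.4-fold lower number from compound 2 to compound 3 (0.13 log units; within the scatter), small and not beyond the scatter. Compound 3 is therefore expected to give about 12000 nM, with a plausible range from 4000 nM to 40000 nM.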

Compound 3, concentration for total growth inhibition: > 100000 nM
Compound 3: no number, only a limit; the forecaster's own chance of this, stated with the estimate: 5%; middle value at least 8.3-fold (0.92 log units) from the limit.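

Going by these compounds alone, the earlier compounds showed only that moving the chloro group on the shared core changes the number. Compound 3 shows what a second chloro group does when it sits on the aromatic carbon between two ring nitrogen atoms: in this assay this single added atom gives an at least 6.1-fold higher number from compound 2 to compound 3 (0.79 log units; beyond the scatter), so here the change weakens growth inhibition. The reading for compound 3 is a limit of the assay and not a number, so the full size of this step stays unknown: the limit of > 100000 nM in this assay, at which 1 of the 3 values shown sits.

The compounds shown carry only hydrogen or chloro on this carbon, so it stays open whether the loss is particular to chloro or follows from any group placed there. An amine or a methoxy group on the same carbon would help separate these two readings.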